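The source may report more compounds than this note shows. Statements on the series, on what has been measured and on what is new or still open speak of the compounds shown alone.

The series rests on one shared core, carried by compound 1 `COc1cc(-c2nn(-c3ccc(NC(=O)Nc4cccc(Cl)c4Cl)cc3)cc2-c2ccncc2)ccc1Cl`, compound 2 `COc1cc(-c2nn(-c3ccc(NC(=O)Nc4ccc(Cl)c(C(F)(F)F)c4)cc3)cc2-c2ccncc2)ccc1Cl`, compound 3 `COc1cc(-c2nn(-c3ccc(NC(=O)Nc4cc(C(F)(F)F)cc(C(F)(F)F)c4)cc3)cc2-c2ccncc2)ccc1Cl` and the still unmeasured compound 4 `COc1cc(-c2nn(-c3ccc(NC(=O)c4cc(Cl)cc(Cl)c4)cc3)cc2-c2ccncc2)ccc1Cl`. In a functional assay on A375P cells (Homo sapiens) for antiproliferative activity, read by MTT assay, with a stated time of 48 h (on this read-out lower numbers stand for stronger inhibition and higher numbers for weaker inhibition), compound 1 returns only a limit, > 20000 nM. Compound 2 gives 14000 nM and compound 3 gives 11800 nM, so compound 2 holds the higher of the two numbers, with compound 3 within the scatter of it. Among the measured compounds shown here, the single measured step, an at least 1.4-fold lower number from compound 1 to compound 2 (0.15 log units; that floor lies within the scatter), is only a floor because compound 1 sits at the limit of > 20000 nM in this assay, at which 1 of the 3 values shown sits. For the measured compounds named here, compound 4 differs from compound 2 by 3,5-dichlorophenyl in place of (4-chloro-3-(trifluoromethyl)phenyl)amino on a carbonyl carbon, a change that no measured step covers, and both numbered values lie close together. No shift beyond the scatter is therefore expected, the step from compound 2 to compound 4 being estimated at a 1.1-fold higher number from compound 2 to compound 4 (0.03 log units; within the scatter). Compound 4 is expected near 15000 nM, between 6000 nM and 40000 nM.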

Compound 4, half-maximal inhibitory concentration: > 20000 nM
Compound 4 was reported as a limit; the forecaster's own chance of this, stated with the estimate: 35%; at least 1.3-fold (0.12 log units) between middle value and limit.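

Placing 3,5-dichlorophenyl directly on the carbonyl carbon, with the amino nitrogen of the leaving group gone, gives an at least 1.4-fold higher number from compound 2 to compound 4 (0.15 log units; that floor lies within the scatter), so no loss beyond the scatter is established. The value of compound 4 is a limit and not a number, which leaves the true size of this step unknown because of where it sits: the limit of > 20000 nM in this assay, at which 2 of the 4 values shown sit. The step from compound 1 to compound 4 joins two limits and cannot be read.

From the compounds shown here alone, compound 4 changes the amino link and the ring substituents together, and their separate contributions stay open. Going by these compounds, how a piperazine or a carboxylic acid on the carbonyl carbon would read in this assay also stays open.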